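The source may hold more compounds than are shown below. What is called first, only, known or untested is meant among the compounds shown, and "the series" means these compounds.

Working notes on the series. Compound 1 `Cc1nc(-c2ccc(C(F)(F)F)cc2)sc1CNc1ccc(CCC(=O)O)cc1`, compound 2 `Cc1nc(-c2ccc(C(F)(F)F)cc2)sc1CNc1ccc(CC(C)C(=O)O)cc1` and compound 3 `Cc1nc(-c2ccc(C(F)(F)F)cc2)sc1CNc1ccc(C(C)CC(=O)O)cc1` share one core and differ only in the chain carried on the aromatic carbon. In a functional assay on CHO cells for agonist activity at Free fatty acid receptor 1 (Homo sapiens), read by a luciferase reporter (a lower number here means a smaller maximal response, a higher number a larger maximal response), compound 1 gives 108%, compound 2 gives 100% and compound 3 gives 109%. On these numbers compound 3 sits alongside the other two rather than apart from them: a number 1 percentage points higher from compound 1 to compound 3 (within the scatter), a number 9 percentage points higher from compound 2 to compound 3 (within the scatter), and the remaining pair, a number 8 percentage points lower from compound 1 to compound 2 (within the scatter), is equally unremarkable. Compound 4 `Cc1nc(-c2ccc(C(F)(F)F)cc2)sc1CNc1ccc([C@H]2C[C@@H]2C(=O)NO)cc1` keeps the core and exchanges the chain: 2-(hydroxycarbamoyl)cyclopropyl in place of 1-(carboxymethyl)ethyl on an aromatic carbon. The three measured steps bear on this change only in part. Each of them moved a methyl within the 2-carboxypropyl or 1-(carboxymethyl)ethyl chain and none shifted the maximal response beyond the scatter, but none exchanged the group itself, introduced a three-membered ring or a hydroxycarbamoyl. The maximal response of compound 4 in this assay is therefore expected close to that of compound 3, with a range widened downward for the untested exchange, so that the expected step is a number 19 percentage points lower from compound 3 to compound 4 (beyond the scatter). Compound 4 is estimated at 90%, between 55% and 115%.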

Compound 4, largest response reached (reported as percent of maximum), in percent of the reference or control that the assay uses: 78%
Compound 4: the middle estimate sits 12 percentage points above what was measured, and the stated range covers the measured number.
By their numbers in this assay, from the lowest: compound 4; then compounds 2, 1 and 3 (each within the scatter of the next).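

The exchange for 2-(hydroxycarbamoyl)cyclopropyl is the only change shown at this aromatic carbon that moves the maximal response in this assay beyond the scatter, with a number 31 percentage points lower from compound 3 to compound 4 (beyond the scatter) and a number 22 percentage points lower from compound 2 to compound 4 (beyond the scatter) and a number 30 percentage points lower from compound 1 to compound 4 (beyond the scatter) among the steps that record it. The position therefore separates a methyl moved along the chain, which left the response within the scatter, from an exchange of the whole chain, which lowered it whichever of the three chains was replaced. Nothing at hand bears on the reason for this fall.

Going by these compounds, the three-membered ring and the hydroxycarbamoyl enter together, so their separate shares in the fall remain open. A three-membered ring carrying a carboxylic acid and an open chain ending in hydroxycarbamoyl would each isolate one of the two.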